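Azole replacement on the shared core: estimate for compound 4

This account rests on a few compounds, and the source may have more. Where it says the series, first, only, none or still open, it means among the compounds named here.

Three analogues on one shared core differ only in the five-membered heteroaryl placed on a saturated chain carbon bound to an aromatic carbon. Compound 1 `CCCCOC(=O)NS(=O)(=O)c1sc(CC(C)C)cc1-c1ccc(Cn2cnc(C(F)(F)F)c2)cc1` gives 7.3 nM in an assay on membranes from uterus for displacement of a labelled ligand from Angiotensin type II receptor (Sus scrofa), with a stated time of 1.5 h; on this read-out higher numbers stand for weaker inhibition and lower numbers for stronger inhibition. Compound 2 `CCCCOC(=O)NS(=O)(=O)c1sc(CC(C)C)cc1-c1ccc(Cn2ncnn2)cc1` gives 16 nM in this assay, and compound 3 `CCCCOC(=O)NS(=O)(=O)c1sc(CC(C)C)cc1-c1ccc(Cn2ccc(C(F)(F)F)n2)cc1` gives 9.5 nM. Compound 3 stands second highest of the three numbers; toward compound 1 the gap is a 1.3-fold higher number from compound 1 to compound 3 (0.11 log units; within the scatter), and toward compound 2 it is a 1.7-fold lower number from compound 2 to compound 3 (0.23 log units; within the scatter), so compound 3 cannot be separated from either on these data. Among the compounds with values here, the only resolved step in the set is a 2.2-fold higher number from compound 1 to compound 2 (0.34 log units; beyond the scatter), a modest loss.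

Compound 4 `CCCCOC(=O)NS(=O)(=O)c1sc(CC(C)C)cc1-c1ccc(Cc2ncco2)cc1` carries the next azole exchange at the same place: 1,3-oxazol-2-yl in place of 3-(trifluoromethyl)-1H-pyrazol-1-yl on a saturated chain carbon bound to an aromatic carbon. Every such exchange so far has shifted the number by a modest amount at most, and the largest shift seen, a 2.2-fold higher number from compound 1 to compound 2 (0.34 log units; beyond the scatter), went with removal of the trifluoromethyl-bearing ring. The change to compound 4 also removes a trifluoromethyl-bearing ring, so a small rise in the number is expected, a 1.6-fold higher number from compound 3 to compound 4 (0.20 log units; within the scatter), while the precedents leave room for no change at all. The estimate for compound 4 in this assay is 15 nM, expected to fall between 6 nM and 40 nM.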

Compound 4, inhibition constant: 3.9 nM
The estimate for compound 4 lay 3.8-fold (0.59 log units) above the measured number; the whole stated range lies above it.
By their numbers in this assay, from the lowest: compounds 4, 1, 3 and 2 (each within the scatter of the next, the first and the last beyond it).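

In this assay, exchanging 3-(trifluoromethyl)-1H-pyrazol-1-yl (9 heavy atoms) for 1,3-oxazol-2-yl (5 heavy atoms) on a saturated chain carbon bound to an aromatic carbon gives a 2.4-fold lower number from compound 3 to compound 4 (0.39 log units; beyond the scatter), so a trifluoromethyl-bearing ring is not needed for a low number at this place. The link between losing the trifluoromethyl-bearing ring and a higher number rested on compound 2 alone; compound 4 goes against it, and the two rings without trifluoromethyl are clearly separated by a 4.1-fold lower number from compound 2 to compound 4 (0.61 log units; beyond the scatter), the largest step in the set, which shows that the identity of the ring matters at this place. The 1,3-oxazol-2-yl ring still cannot be separated from 4-(trifluoromethyl)-1H-imidazol-1-yl, with a 1.9-fold lower number from compound 1 to compound 4 (0.27 log units; within the scatter), so the smaller ring matches that trifluoromethyl-bearing ring on these data but cannot be said to improve on it.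

Nothing available explains why the 1,3-oxazol-2-yl ring and the 2H-tetrazol-2-yl ring differ in this assay. As far as these compounds go, it remains open how a methyl group, an amine or a trifluoromethyl group on the 1,3-oxazol-2-yl ring would move the number, and whether a longer chain in place of the saturated chain carbon would preserve it.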